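The compounds below may be only part of what the source reports. "The series", "measured", "known", "first", "only" and "open" are said of these compounds alone.

Of the compounds shown here, two built on a shared core have so far been measured in a functional assay on NCI-H520 cells (Homo sapiens) for inhibition, read by MTT assay, with a stated time of 48 h, tested at 10 uM; a higher number here means more inhibition at the concentration tested (going by the name of the read-out), a lower number less inhibition. Compound 1 `COc1cc(Br)ccc1Nc1cc(NC(=O)Nc2c(Cl)cccc2Cl)ncn1` gives 29.1% in this assay, and compound 2 `COc1ccc(Br)cc1Nc1cc(NC(=O)Nc2c(Cl)cccc2Cl)ncn1` gives 45%. For the measured compounds named here, compound 2 therefore stands highest of the two numbers, and the only measured step, a number 15.9 percentage points higher from compound 1 to compound 2 (beyond the scatter), separates it from compound 1, its nearest neighbour.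

Compound 3 `CCc1ccc(Nc2cc(NC(=O)Nc3c(Cl)cccc3Cl)ncn2)cc1` has not yet been measured in this assay. It differs from compound 2 by 4-ethylphenyl in place of 5-bromo-2-methoxyphenyl on a nitrogen on an aromatic ring. Going by the values given here, the single measured step bears on this only loosely: it moved a bromine within the same ring while keeping the methoxy group, whereas the change to compound 3 removes both the bromine and the methoxy group and brings in an ethyl chain on a ring with no hydrogen-bond acceptor. Among the compounds with values here, with no measured step of that kind, there is no basis for predicting a shift beyond the scatter in either direction, and the estimated step of a number 10 percentage points lower from compound 2 to compound 3 (within the scatter) is accordingly small. Compound 3 is therefore expected to give about 35% in this assay, within a wide range from 10% to 60%.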

Compound 3, a percentage reported as inhibition, at one concentration (the size of the read-out at that concentration, not a potency): 31.5%
Beside the measured number, compound 3's estimate is 3.5 percentage points above it; the range from low to high includes it.
By their numbers in this assay, from the lowest: compounds 1 and 3 (each within the scatter of the next); then compound 2.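

In this assay, the change at this place on a nitrogen on an aromatic ring gives a number 13.5 percentage points lower from compound 2 to compound 3 (beyond the scatter), so compound 2 now stands apart from both other compounds, with its 5-bromo-2-methoxyphenyl group alone giving the highest number. The second new step, a number 2.4 percentage points higher from compound 1 to compound 3 (within the scatter), shows that 4-ethylphenyl, which carries neither bromine nor oxygen, cannot be told apart from 4-bromo-2-methoxyphenyl here, so having those two substituents on the ring does not by itself give the higher number, as compound 1 carries both and still reads with compound 3. No measurement offered here explains why the 5-bromo-2-methoxyphenyl group stands apart.

The compounds shown leave open whether the bromine or the methoxy group accounts for the higher number of compound 2, since both leave together in the step to compound 3 and no ring carrying only one of them appears. They also leave open how this place responds to quite different groups, such as an amine, a carboxylic acid or a longer alkyl chain in place of the ethyl group.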